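The compounds below may be only part of what the source reports. "The series", "measured", "known", "first", "only" and "open" are said of these compounds alone.

Measured so far:
- compound 1 `Cc1ccc(S(=O)(=O)NC(=O)Nc2ccc(Cl)c(Cl)c2)s1`: 24%
- compound 2 `CCCc1ccc(S(=O)(=O)NC(=O)Nc2ccc(Cl)cc2)s1`: 38%
- compound 3 `CCc1ccc(S(=O)(=O)NC(=O)Nc2ccc(Cl)cc2)o1`: 57%

All three compounds were tested in a functional assay on the whole organism (6C3HED cells, Mus musculus) for inhibition, at a dose of 150 mg/kg by the oral route; a higher number here means more inhibition at the dose given (going by the name of the read-out), a lower number less inhibition. Compound 3 gives the highest of the three numbers; compound 2 sits closer to it than compound 1, and both of those gaps are beyond the usual scatter of repeat measurements, so compound 3 gives the highest inhibition in this assay of the three at this dose.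

Compound 4 `Cc1cc(S(=O)(=O)NC(=O)Nc2ccc(Cl)cc2)sc1C` has not yet been measured. It differs from compound 3 in one place:

4,5-dimethylthiophen-2-yl in place of 5-ethylfuran-2-yl on a sulfonyl sulfur

Among the compounds with values here, no step between two measured compounds that differ in exactly one place is known here, so the size of this change cannot be read off directly. What can be said is that the two measured compounds whose structures carry a sulfur-containing five-membered ring, compound 1 and compound 2, both gave lower numbers than compound 3. On that basis a downward step of moderate size is expected, a number 15 percentage points lower from compound 3 to compound 4 (beyond the scatter), rather than no change. Compound 4 is therefore expected to give about 42%, with a likely range from 22% to 62%.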

Compound 4, a percentage reported as inhibition, in the whole organism at one dose (the size of the read-out at that dose, not a potency): 42%
The estimate for compound 4 equals the measured number at the digits printed, within the range that was stated.
By their numbers in this assay, from the lowest: compound 1; then compounds 2 and 4 (each within the scatter of the next); then compound 3.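

In this assay, within the data shown here, the group on the sulfonyl sulfur can now be compared directly for the first time, and the step is (a number 15 percentage points lower from compound 3 to compound 4 (beyond the scatter)), so the result at this position depends on which group sits there. The two groups match in heavy-atom count and in hydrogen-bond donors and acceptors, and each is a five-membered aromatic ring, so those matching counts do not protect the number from falling. No measurement here bears on why the number falls.

The change replaces the ring oxygen with sulfur and the ethyl with two methyl groups in a single step, so the share of each remains unresolved. A 5-ethylthiophen-2-yl or a 4,5-dimethylfuran-2-yl group at the same place would separate these two parts of the change.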